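This account rests on a few compounds, and the source may have more. Where it says the series, first, only, none or still open, it means among the compounds named here.

Compounds measured so far:
compound 1, `O=C1C=C(NCc2ccccc2)C(=O)c2c1nc1n2[C@H]2OC[C@@H](O)[C@H]2OC1`;
compound 2, `CCc1ccc(NC2=CC(=O)c3nc4n(c3C2=O)[C@H]2OC[C@@H](O)[C@H]2OC4)cc1`;
compound 3, `CCOc1ccccc1NC1=CC(=O)c2nc3n(c2C1=O)[C@H]1OC[C@@H](O)[C@H]1OC3`.

In a functional assay on ECa-109 cells for inhibition, with ECa-109 cell line (Homo sapiens) as the target, read by sulforhodamine B assay (on this read-out higher numbers stand for weaker inhibition and lower numbers for stronger inhibition), compound 1 gives only a limit, > 8000 nM. Compound 2 gives 3080 nM. Compound 3 gives 4630 nM. Of the two numbers, compound 3 has the higher one, with compound 2 nearest; the gap a 1.5-fold higher number from compound 2 to compound 3 (0.18 log units; within the scatter) lies within the scatter. The step of an at least 2.5-fold lower number from compound 1 to compound 2 (0.41 log units; beyond the scatter) is beyond the scatter and rests on (the limit of > 8000 nM in this assay, at which 1 of the 3 values shown sits). The step of an at least 1.7-fold lower number from compound 1 to compound 3 (0.23 log units; that floor lies within the scatter) has a floor that lies within the scatter.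

Compound 4, `O=C1C=C(Nc2ccc(Br)cc2)C(=O)c2c1nc1n2[C@H]2OC[C@@H](O)[C@H]2OC1`, is not yet measured. The change from compound 3: 4-bromophenyl in place of 2-ethoxyphenyl on an amine nitrogen. The step that bears on it is a 1.5-fold higher number from compound 2 to compound 3 (0.18 log units; within the scatter), an exchange of one substituted phenyl for another on the same nitrogen that stayed within the scatter. For the measured compounds named here, no measured step introduces a bromine, so the expectation rests on that single comparison. In this assay a step within the scatter is expected, estimated as a 1.3-fold lower number from compound 3 to compound 4 (0.12 log units; within the scatter). Compound 4 is expected to give about 3500 nM, within a range of 1500 nM to 8000 nM.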

Compound 4, half-maximal inhibitory concentration: 2850 nM
Compound 4: middle estimate off by 1.2-fold (0.09 log units), on the high side; the measured number falls inside the stated range.
By their numbers in this assay, from the lowest: compounds 4, 2 and 3 (each within the scatter of the next). At a limit, above all of these: compound 1.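

In this assay, bromo in place of ethyl on an aromatic carbon gives no readable change, a 1.1-fold lower number from compound 2 to compound 4 (0.03 log units; within the scatter). The exchange on the amine nitrogen that removes the ether oxygen and brings in bromine is also unreadable, a 1.6-fold lower number from compound 3 to compound 4 (0.21 log units; within the scatter), so compounds 2, 3 and 4 all lie within the scatter of one another. As with compound 2, and unlike compound 3, whose step from benzyl has a floor within the scatter, the substituted phenyl here stands clear of benzyl, an at least 2.8-fold lower number from compound 1 to compound 4 (0.44 log units; beyond the scatter), and that step rests on a limit: the limit of > 8000 nM in this assay, at which 1 of the 4 values shown sits.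

Going by these compounds, whether an unsubstituted phenyl, or an amine or a carboxylic acid on the phenyl ring, would leave these numbers unchanged stays open. So does the effect of moving ethoxy from the 2-position to the 4-position of the phenyl.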